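The source may report more compounds than this note shows. Statements on the series, on what has been measured and on what is new or still open speak of the compounds shown alone.

Three compounds share one core and differ only in the aromatic group carried on a saturated chain carbon, two bonds along the chain from a carbonyl carbon. Compound 1 `CC(C)C[C@H](N)c1cc(C(F)(F)F)ccc1N1CCN(C(=O)CCc2ccccc2O)CC1` bears a 2-hydroxyphenyl there, and in an assay on HEK293 cells for displacement of a labelled ligand from Melanocortin receptor 4 (Homo sapiens) (a lower number here means a stronger inhibitor, a higher number a weaker inhibitor), compound 1 gives 3300 nM. Compound 2 `CC(C)C[C@H](N)c1cc(C(F)(F)F)ccc1N1CCN(C(=O)CCc2ccc(S(C)(=O)=O)cc2)CC1` carries a 4-(methylsulfonyl)phenyl at that place, and in this assay compound 2 gives 4900 nM. Compound 3 `COc1cc(OC)c(OC)cc1CCC(=O)N1CCN(c2ccc(C(F)(F)F)cc2[C@@H](N)CC(C)C)CC1` carries a 2,4,5-trimethoxyphenyl, and in this assay compound 3 gives 6100 nM, the highest of the three numbers, yet its gaps to the other two stay within the scatter: a 1.8-fold higher number from compound 1 to compound 3 (0.27 log units; within the scatter) and a 1.2-fold higher number from compound 2 to compound 3 (0.10 log units; within the scatter), while a 1.5-fold higher number from compound 1 to compound 2 (0.17 log units; within the scatter). Compound 4 `CC(C)C[C@H](N)c1cc(C(F)(F)F)ccc1N1CCN(C(=O)CCc2cccs2)CC1` makes a further exchange at the same place: thiophen-2-yl in place of 2,4,5-trimethoxyphenyl on a saturated chain carbon, two bonds along the chain from a carbonyl carbon. Each swap made so far at this position left the number essentially where it was, so for compound 4 the step of a 1.2-fold lower number from compound 3 to compound 4 (0.09 log units; within the scatter) is expected to be no larger than the scatter. On that basis compound 4 is estimated to give 5000 nM in this assay, with a range from 1500 nM to 15000 nM.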

Compound 4, inhibition constant: 4600 nM
Estimate against measurement, compound 4: 1.1-fold (0.04 log units) above; the range from low to high includes it.
By their numbers in this assay, from the lowest: compounds 1, 4, 2 and 3 (each within the scatter of the next).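

Thiophen-2-yl is the first group in this set that is not a six-membered aromatic ring of carbon only: it is a five-membered aromatic ring with 1 hetero atom, and it has 5 heavy atoms, fewer than the 2,4,5-trimethoxyphenyl it replaces. Even so, in this assay all three new comparisons stay within the scatter, with a 1.3-fold lower number from compound 3 to compound 4 (0.12 log units; within the scatter) and a 1.1-fold lower number from compound 2 to compound 4 (0.03 log units; within the scatter) and a 1.4-fold higher number from compound 1 to compound 4 (0.14 log units; within the scatter). Nothing available explains why the numbers stay so close together.

Going by these compounds, all four compounds carry an aromatic ring at this place, so it remains open how the number would respond to an amine, a carboxylic acid or a longer chain there. On these data alone, it also remains open whether any group at this position can move the number beyond the scatter.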